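This account rests on a few compounds, and the source may have more. Where it says the series, first, only, none or still open, it means among the compounds named here.

In an ADME assay on HEK293 cells (Homo sapiens) for cytotoxicity, read by resazurin assay, with a stated time of 72 h (a lower number here means that less compound is tolerated, a higher number that more compound is tolerated), compound 1 (`COc1cccc(CNC(=O)c2nc3ccc(F)c(OCCc4ccc(N)cc4)c3c(=O)[nH]2)c1`) gives > 20000 nM as a limit of the assay, not a number. Compound 2 (`O=C(O)c1ccc(CCOc2c(F)ccc3nc(C(=O)NCc4ccccc4)[nH]c(=O)c23)cc1`) gives > 20000 nM as a limit too, so it stands without a number. Among the measured compounds shown here, all that is in hand so far is this (the limit of > 20000 nM in this assay, at which 2 of the 2 values shown sit), and no measured pair shows a single change. Compound 3 (`O=C(O)c1ccc(CCOc2c(F)ccc3nc(C(=O)NCC4CCCCC4)[nH]c(=O)c23)cc1`) carries the change cyclohexyl in place of phenyl on a saturated chain carbon bound to an amide-type nitrogen in which cyclohexyl replaces phenyl on a saturated chain carbon bound to an amide-type nitrogen. In this assay a step of a number no higher from compound 2 to compound 3 (the limit leaves the size open) is expected, with nothing beyond the usual scatter. Compound 3 is estimated at 20000 nM with an expected range from 10000 nM to 40000 nM and will probably be reported only as a limit.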

Compound 3, half-maximal cytotoxic concentration in the HEK293 assay: > 20000 nM
Compound 3 ended at the assay's limit (the forecaster's own chance of this, stated with the estimate: 80%); the middle value sits exactly at the limit.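

In the HEK293 assay compound 2 gives > 20000 nM as a limit of the assay, not a number. In the HEK293 assay compound 3 gives > 20000 nM as a limit too, not a number. Among the compounds shown here, with a limit for both compounds, no step between them can be read. The compounds shown leave open what concentration of any of them would reach the half-maximal cytotoxic read-out. In a physicochemical assay for solubility, read by nephelometry, in phosphate buffer, measured as kinetic solubility, at pH 6.5 (a lower number here means a less soluble compound, a higher number a more soluble compound), compound 2 gives 6.3 ug/mL as a measured number. In the physicochemical assay compound 3 gives < 1.6 ug/mL as a limit of the assay, not a number. In the physicochemical assay cyclohexyl in place of phenyl on a saturated chain carbon bound to an amide-type nitrogen goes with an at least 3.9-fold lower number from compound 2 to compound 3 (0.59 log units; beyond the scatter) in this comparison.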